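Does a chlorine swap stay at the assay limit?

The source may hold more compounds than are shown below. What is called first, only, known or untested is meant among the compounds shown, and "the series" means these compounds.

Measured in an ADME assay on BJ cells (Homo sapiens) for cytotoxicity, with a stated time of 72 h; a higher number here means that more compound is needed for the effect, a lower number that less compound is needed:
Compound 1 `C=C[C@@](C)(/C=C/c1ccc(OC)cc1)CCC=C(C)C`: > 36600 nM (a limit)
Compound 2 `C=C[C@@](C)(/C=C/c1ccc(Nc2ccc(OC)c(F)c2)cc1)CCC=C(C)C`: > 36600 nM (a limit)
Compound 3 `C=C[C@@](C)(/C=C/c1ccc(Nc2ccc(F)c(F)c2)cc1)CCC=C(C)C`: > 36600 nM (a limit)

In this assay compound 3 gives > 36600 nM, which is a limit and not a number. It shares this position with the other two compounds: the limit of > 36600 nM in this assay, at which 3 of the 3 values shown sit. None of the three can therefore be ranked against the others.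

The next structure is compound 4 `C=C[C@@](C)(/C=C/c1ccc(Nc2ccc(Cl)cc2)cc1)CCC=C(C)C`, in which 4-chlorophenyl stands in place of 3,4-difluorophenyl on a nitrogen on an aromatic ring: 4-chlorophenyl in place of 3,4-difluorophenyl on a nitrogen on an aromatic ring.

Going by the values given here, two measured steps bear on this change. The closer one alters the same outer ring, and it is a step that the two limits leave unreadable from compound 2 to compound 3. The other replaces the whole amino group, and it is a step that the two limits leave unreadable from compound 1 to compound 3. Neither has a readable size, so neither gives a size to carry over. Among the compounds with values here, they show only that these changes all left the compounds at the limit. The swap to compound 4 is of a similar kind, so no real step is expected in this assay, in either direction, and another limit is the most likely result. A measurable number remains possible.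

For compound 4 the estimated value is 36600 nM, with an expected range from 15000 nM to 80000 nM. This estimate means an expected a number no higher from compound 3 to compound 4 (the limit leaves the size open).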

Compound 4, half-maximal effective concentration: > 36600 nM
Compound 4 ended at the assay's limit (the forecaster's own chance of this, stated with the estimate: 75%); the middle value lies on the limit itself.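

Compound 4 also gives only a limit in this assay, so its steps from compound 1, compound 2 and compound 3 cannot be read, and none of the four compounds can be ranked against the others: the limit of > 36600 nM in this assay, at which 4 of the 4 values shown sit.

The compounds shown leave open how much of any of these structures is needed for the effect, and whether any change to the outer ring alters that amount.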